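This account rests on a few compounds, and the source may have more. Where it says the series, first, only, none or still open, it means among the compounds named here.

Measured compounds in a functional assay on SK-BR-3 cells (Homo sapiens) for antiproliferative activity, read by MTT assay, with a stated time of 48 h; on this read-out higher numbers stand for weaker inhibition and lower numbers for stronger inhibition: compound 1 `COc1ccc(C(=O)Nc2ccc(N(C)S(C)(=O)=O)c(OCc3cc(Cl)ccc3Cl)c2)cc1` gives 490 nM; compound 2 `CN(c1ccc(NC(=O)c2ccc(I)cc2)cc1OCc1cc(Cl)ccc1Cl)S(C)(=O)=O` gives 660 nM; compound 3 `CN(c1ccc(NC(=O)c2ccc3ccccc3c2)cc1OCc1cc(Cl)ccc1Cl)S(C)(=O)=O` gives 2210 nM.

Compound 3 stands at the highest number of the three, with a 3.3-fold higher number from compound 2 to compound 3 (0.52 log units; beyond the scatter) and a 4.5-fold higher number from compound 1 to compound 3 (0.65 log units; beyond the scatter). Those two steps, and a 1.3-fold higher number from compound 1 to compound 2 (0.13 log units; within the scatter), all concern the group on the carbonyl carbon; the benzyloxy side was held fixed throughout. Compound 4 `Cc1ccc(C(F)(F)F)cc1COc1cc(NC(=O)c2ccc3ccccc3c2)ccc1N(C)S(C)(=O)=O` keeps the naphthalen-2-yl amide of compound 3 and alters that fixed side: 2-methyl-5-(trifluoromethyl)phenyl in place of 2,5-dichlorophenyl on a saturated chain carbon bound to an oxygen on an aromatic ring. Among the measured compounds shown here, no measured step bears on this position, so neither direction nor size can be read from the series, and a result within the scatter of compound 3 is the working assumption. Compound 4 is therefore expected to give 2400 nM, range 800 nM to 7000 nM, which is expected to mean a 1.1-fold higher number from compound 3 to compound 4 (0.04 log units; within the scatter).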

Compound 4, half-maximal inhibitory concentration: 18400 nM
For compound 4 the middle estimate is 7.7-fold (0.88 log units) below the measured one, outside the stated range (above it).
By their numbers in this assay, from the lowest: compounds 1 and 2 (each within the scatter of the next); then compound 3; then compound 4.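

The benzyloxy side is not a silent position: 2-methyl-5-(trifluoromethyl)phenyl in place of 2,5-dichlorophenyl gives an 8.3-fold higher number from compound 3 to compound 4 (0.92 log units; beyond the scatter) and so weakens inhibition by more than any step at the carbonyl carbon. Nothing measured on hand accounts for this step.

The compounds shown do not separate the contribution of the methyl from that of the trifluoromethyl. Also open, going by these compounds, are how an amine or a carboxylic acid on this ring would read, and whether the same change carries over to the 4-methoxyphenyl amide of compound 1.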